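The source may report more compounds than this note shows. Statements on the series, on what has been measured and on what is new or still open speak of the compounds shown alone.

Of the compounds shown here, three of this study have been measured in a functional assay on the whole organism (Tail, strain ICR) with Mus musculus as the target, in the tail flick test, with a stated time of 150 min, at a dose of 25 umol/kg by the oral route; on this read-out lower numbers stand for a weaker effect and higher numbers for a stronger effect at the one dose given. Compound 1, `NC(=O)CC[C@H](NC(=O)CN(c1ncnc2c1ncn2C1CCCCO1)C1CC1)C(=O)OCc1ccccc1`, gives 10.7% in this assay. Compound 2, `C[C@@H](O)[C@H](NC(=O)CN(c1nc(Cl)nc2[nH]cnc12)C1CC1)C(=O)OCc1ccccc1`, gives 12.8% in this assay, and compound 3, `NC(=O)C[C@H](NC(=O)CN(c1nc(Cl)nc2[nH]cnc12)C1CC1)C(=O)O`, gives 7.51% in this assay. Compound 1 holds the second highest of the three numbers; the nearest to it is compound 2, which lies within the usual scatter of it, and the furthest is compound 3, which also lies within the scatter, so this read-out does not tell the three apart.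

Compound 4, `CSCC[C@H](NC(=O)CN(c1ncnc2c1ncn2C1CCCCO1)C1CC1)C(=O)OCc1ccccc1`, differs from compound 1 in one place: methylsulfanyl in place of carbamoyl on a saturated chain carbon, three bonds along the chain from an amide-type nitrogen and a carbonyl carbon. Within the data shown here, no pair of measured compounds separated by a single change of this kind is at hand, so the size of the step rests on the spread seen so far, where compounds 1, 2 and 3, though differing in several places, all sit within the scatter of one another. On that basis the step is expected to be small in this assay, none beyond the scatter. The step from compound 1 to compound 4 is expected to be a number 1.3 percentage points higher from compound 1 to compound 4 (within the scatter). Compound 4 is therefore expected to give 12% in this assay, with a range from 4% to 22%.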

Compound 4, a percentage reported as activity, at one dose (the size of the read-out at that dose, not a potency): 17.5%
Compound 4: middle estimate off by 5.5 percentage points, on the low side, and the stated range covers the measured number.
By their numbers in this assay, from the lowest: compounds 3, 1, 2 and 4 (each within the scatter of the next).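

In this assay, among these compounds, the first change read in one place gives a number 6.8 percentage points higher from compound 1 to compound 4 (within the scatter) and so gives a direct measure at this saturated chain carbon, which the earlier compounds, differing in several places, could not provide. Exchanging carbamoyl, with its hydrogen-bond donor, for methylsulfanyl, which has none, does not separate compound 4 from compound 1 on this read-out. The compounds shown offer no measured property that could account for the size of this step.

From the compounds shown here alone, whether an amine, a carboxylic acid or a longer chain on this carbon would also stay within the scatter remains open. Also open, going by these compounds, is whether the same exchange of carbamoyl for methylsulfanyl would read alike on the core of compound 2 or compound 3.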